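Acylating the amine of compound 3

The source may hold more compounds than are shown below. What is called first, only, known or untested is meant among the compounds shown, and "the series" means these compounds.

Values in a functional assay (aorta) with Rattus norvegicus as the target; a lower number here means that less compound is needed, a higher number that more compound is needed for the effect
Compound 1 `COc1ccc(-c2nc(/N=C(\N)NC3CCCCC3)sc2-c2ccc(OC)cc2)cc1` gives > 100 uM (a limit of the assay)
Compound 2 `COc1ccc(-c2nc(CN(C)C)sc2-c2ccc(OC)cc2)cc1` gives 8.4 uM
Compound 3 `COc1ccc(-c2nc(CN)sc2-c2ccc(OC)cc2)cc1` gives 7.7 uM

Compound 3 and compound 2 lie within the scatter of each other, and both stand clear of the limit of compound 1. Compound 4 `COc1ccc(-c2nc(CNC(=O)CSc3ccccc3)sc2-c2ccc(OC)cc2)cc1` follows from compound 3 with ((phenylsulfanyl)methyl)carbonyl in place of hydrogen on an amine nitrogen. The small change a 1.1-fold lower number from compound 2 to compound 3 (0.04 log units; within the scatter) stays within the scatter. The change of a much larger group an at least 12-fold lower number from compound 1 to compound 3 (1.11 log units; beyond the scatter) is large and rests on (the limit of > 100 uM in this assay, at which 1 of the 3 values shown sits). That larger group sits elsewhere, so it guides only the direction. A moderate rise in the number is therefore expected, an estimated 2.6-fold higher number from compound 3 to compound 4 (0.41 log units; beyond the scatter) in this assay. Compound 4 is expected at an estimated 20 uM, within a range of 4 uM to 100 uM.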

Compound 4, concentration for half-maximal effect: 4.2 uM
Estimate against measurement, compound 4: 4.8-fold (0.68 log units) above, and the stated range covers the measured number.
By their numbers in this assay, from the lowest: compounds 4, 3 and 2 (each within the scatter of the next). At a limit, above all of these: compound 1.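

In this assay, the amine nitrogen of compound 3 carries the much larger ((phenylsulfanyl)methyl)carbonyl group with no change beyond the scatter (a 1.8-fold lower number from compound 3 to compound 4 (0.26 log units; within the scatter)). The comparison with the dimethylamino group reads the same (a 2.0-fold lower number from compound 2 to compound 4 (0.30 log units; within the scatter)), so the free amino group of compound 3 is not required for a number in this range. Nothing available gives a cause for this result. Still open, on these data alone, is how an acetyl group, or an oxygen in place of the sulfur, would read at this nitrogen. As far as these compounds go, the effect of a carboxylic acid on the added phenyl ring also remains open.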